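A few compounds are considered here, and "the series" means these few. Any claim that something is new, unique, unknown or untested is made for them only; others in the source may bear on it.

Three compounds share one core and differ only in the group carried on an amine nitrogen in a ring. In an assay on CHO cells for displacement of a labelled ligand from 5-hydroxytryptamine receptor 7 (Homo sapiens) (on this read-out higher numbers stand for weaker inhibition and lower numbers for stronger inhibition), compound 1 `COc1ccc(S(=O)(=O)NCCCN2CCN(c3cccc(C(F)(F)F)c3)CC2)cc1` gives 89 nM, compound 2 `COc1ccc(S(=O)(=O)NCCCN2CCN(c3cccc(OC)c3)CC2)cc1` gives 339 nM, and compound 3 `COc1ccc(N2CCN(CCCNS(=O)(=O)c3ccc(OC)cc3)CC2)cc1` gives 9310 nM. On these numbers compound 2 stands second highest of the three: the step of a 3.8-fold higher number from compound 1 to compound 2 (0.58 log units; beyond the scatter) separates it from compound 1, while the step of a 27-fold higher number from compound 2 to compound 3 (1.44 log units; beyond the scatter) separates it from compound 3.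

Compound 4 `COc1ccc(S(=O)(=O)NCCCN2CCN(c3ccccc3)CC2)cc1` has not been measured. It differs from compound 2 by hydrogen in place of methoxy on an aromatic carbon, on an aromatic carbon of a six-membered aromatic ring of carbon only, meta to a large group; read one bond further out, 3-methoxyphenyl becomes phenyl. For the measured compounds named here, two measured steps bear on this. Exchanging one group for another at that carbon gave a 3.8-fold higher number from compound 1 to compound 2 (0.58 log units; beyond the scatter), a modest step; moving the methoxy to a different carbon gave a 27-fold higher number from compound 2 to compound 3 (1.44 log units; beyond the scatter), a large one. Removing the methoxy altogether leaves the position bare, a case neither step covers directly. A modest weakening is expected, a 1.9-fold higher number from compound 2 to compound 4 (0.28 log units; within the scatter). Compound 4 is therefore estimated at 650 nM in this assay, within 250 nM to 1700 nM.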

Compound 4, half-maximal inhibitory concentration: > 10000 nM
Compound 4: only a limit was reported; the forecaster's own chance of this, stated with the estimate: 2%; middle value at least 15-fold (1.18 log units) from the limit.
By their numbers in this assay, from the lowest: compound 1; then compound 2; then compound 3. At a limit, above all of these: compound 4.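

Compound 4 sits at a limit of the assay, not at a number: the limit of > 10000 nM in this assay, at which 1 of the 4 values shown sits. For the compounds shown here, the earlier compounds showed only that trading one group for another at this carbon shifts the number modestly, whereas leaving the carbon bare costs far more, with an at least 29-fold higher number from compound 2 to compound 4 (1.46 log units; beyond the scatter) and an at least 110-fold higher number from compound 1 to compound 4 (2.05 log units; beyond the scatter), so in these compounds having trifluoromethyl or methoxy here counts for more than which of the two it is. The bare phenyl cannot be ranked against 4-methoxyphenyl: the step reads an at least 1.0-fold higher number from compound 3 to compound 4 (0.03 log units; that floor lies within the scatter).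

Only trifluoromethyl and methoxy are shown on this carbon, so it remains open whether a smaller group such as a methyl or a single fluorine would be enough to keep the number close to those of compound 1 and compound 2. On these data alone, it is equally open how an amine or a hydroxyl at this carbon would read.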